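Swapping the Amide Substituent on a Quinazoline Piperidine Series

A few compounds are considered here, and "the series" means these few. Any claim that something is new, unique, unknown or untested is made for them only; others in the source may bear on it.

Compound 1 `CCNC(=O)C1CCN(c2nc(N)c3cc(OC)c(OC)cc3n2)CC1` — 1.64 nM
Compound 2 `CCN(CC)C(=O)C1CCN(c2nc(N)c3cc(OC)c(OC)cc3n2)CC1` — 1.11 nM
Compound 3 `COc1cc2nc(N3CCC(C(=O)N(C)Cc4ccccc4)CC3)nc(N)c2cc1OC` — 0.2 nM

All three compounds share the same core and differ only in the group attached to the carbonyl carbon of the amide. In an assay on isolated protein for displacement of a labelled ligand from Adrenergic receptor alpha-1 (Rattus norvegicus) (a lower number here means a stronger inhibitor, a higher number a weaker inhibitor), compound 3 gives 0.2 nM, the strongest of the three: the steps of an 8.2-fold lower number from compound 1 to compound 3 (0.91 log units; beyond the scatter) and a 5.6-fold lower number from compound 2 to compound 3 (0.74 log units; beyond the scatter) both lie beyond the scatter, while the step of a 1.5-fold lower number from compound 1 to compound 2 (0.17 log units; within the scatter) does not.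

Compound 4 `COc1cc2nc(N3CCC(C(=O)NCCOc4ccccc4)CC3)nc(N)c2cc1OC` carries the change ((2-phenoxyethyl)amino in place of benzyl(methyl)amino on a carbonyl carbon). Within the data shown here, no measured step covers this exact exchange. The two steps that bear on it both show that moving from a small alkyl amide to the benzyl(methyl) amide lowered the number modestly. Compound 4 keeps an aromatic ring but returns to an amide with a hydrogen on its nitrogen, as in compound 1, so a modest rise in the number is expected, yet not a full return to where compound 1 stands. The estimated step is a 3.0-fold higher number from compound 3 to compound 4 (0.48 log units; beyond the scatter). For compound 4 the estimate in this assay is 0.6 nM, with a range from 0.2 nM to 2 nM.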

Compound 4, inhibition constant: 0.42 nM
The estimate for compound 4 lay 1.4-fold (0.15 log units) above the measured number; the range from low to high includes it.
By their numbers in this assay, from the lowest: compound 3; then compound 4; then compounds 2 and 1 (each within the scatter of the next).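

In this assay an amide that keeps its hydrogen can still give a low number at this carbonyl carbon: (2-phenoxyethyl)amino brings a 3.9-fold lower number from compound 1 to compound 4 (0.59 log units; beyond the scatter) and so goes well past the ethylamino group. Both groups carrying an aromatic ring now stand below the small alkyl amides, with a 2.6-fold lower number from compound 2 to compound 4 (0.42 log units; beyond the scatter) adding to that picture and no compound shown going against it, although a 2.1-fold higher number from compound 3 to compound 4 (0.32 log units; beyond the scatter) leaves benzyl(methyl)amino ahead. No measurement offered here accounts for these differences.

As far as these compounds go, whether the chain oxygen matters remains open, and a (3-phenylpropyl)amino group, with a carbon in its place, would address that. Also open, from the compounds shown here alone, is what a methyl on the amide nitrogen of the (2-phenoxyethyl)amino group would do, since compound 3 and compound 4 differ in more than that one feature.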